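Working notes: urea to amide step, compound 2 to compound 3

The source may report more compounds than this note shows. Statements on the series, on what has been measured and on what is new or still open speak of the compounds shown alone.

compound 1 `O=C(Nc1cccc(-n2cc(-c3ccncc3)c(-c3cc(O)cc(Cl)c3)n2)c1)Nc1ccc(Cl)c(Cl)c1`: -88%
compound 2 `COc1cc(Cl)cc(-c2nn(-c3cccc(NC(=O)Nc4ccc(Cl)c(Cl)c4)c3)cc2-c2ccncc2)c1`: -100%

In a functional assay on COLO 205 cells (Homo sapiens) for inhibition, read by sulforhodamine B assay, with a stated time of 48 h, tested at 100 uM (a lower number here means a stronger effect, a higher number a weaker effect of the compound at the concentration tested), compound 2 gives -100%, the lowest of the two numbers; compound 1 gives -88%, and the gap between them is beyond the scatter.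

Compound 3 `COc1cc(Cl)cc(-c2nn(-c3cccc(NC(=O)c4cccc(C(F)(F)F)c4)c3)cc2-c2ccncc2)c1` differs from compound 2 by 3-(trifluoromethyl)phenyl in place of (3,4-dichlorophenyl)amino on a carbonyl carbon. Within the data shown here, the only measured step, a number 12 percentage points lower from compound 1 to compound 2 (beyond the scatter), concerns an oxygen on an aromatic ring, not the carbonyl carbon, so it does not bear on this change. Among the measured compounds shown here, no measured step covers it, and the expectation is wide. A step of a number 30 percentage points higher from compound 2 to compound 3 (beyond the scatter) towards a weaker effect is expected. Compound 3 is estimated at -70%, range -100% to -20%.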

Compound 3, a percentage reported as activity, at one concentration (the size of the read-out at that concentration, not a potency): 45%
For compound 3 the middle estimate is 115 percentage points below the measured one; measured number outside the range, above it.
By their numbers in this assay, from the lowest: compound 2; then compound 1; then compound 3.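

In this assay, 3-(trifluoromethyl)phenyl in place of (3,4-dichlorophenyl)amino on the carbonyl carbon gives a number 145 percentage points higher from compound 2 to compound 3 (beyond the scatter), a large move towards a weaker effect, so this position is not tolerant of every aromatic group. The change swaps the amino link and its hydrogen-bond donor and also the chlorines for trifluoromethyl, and this single step cannot separate these parts. Nothing available accounts for the size of this step.

Still open, as far as these compounds go, is which part of the change carries the step. Also open, from the compounds shown here alone, is how the carbonyl carbon responds to a non-aromatic group such as morpholine or a cyclohexylamino group.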